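The compounds below may be only part of what the source reports. "The series", "measured", "known", "first", "only" and "open" are said of these compounds alone.

Compound 1 `COc1cc(N2CCN(c3cc(OC)c(OC)c(OC)c3)CC2)cc(OC)c1OC`: 12500 nM
Compound 2 `CCC(CC)C(=O)OCC1CN(Cc2cc(OC)c(OC)c(OC)c2)CCN1Cc1cc(OC)c(OC)c(OC)c1`: 2700 nM
Compound 3 `COc1cc(C(=O)N2CCN(C(=O)c3cc(OC)c(OC)c(OC)c3)C(COC(=O)NC(C)(C)C)C2)cc(OC)c1OC`: 130 nM

All three were tested in a functional assay (Oryctolagus cuniculus) for inhibition of platelet-activating factor receptor (Cavia porcellus); a lower number here means a stronger inhibitor, a higher number a weaker inhibitor. Compound 3 gives the lowest number of the three, and its gaps to compound 2 and to compound 1 both lie beyond the usual scatter, so it is the strongest inhibitor in this set. The next compound, compound 4 `CCCCN(CCCC)C(=O)OCC1CN(C(=O)c2cc(OC)c(OC)c(OC)c2)CCN1C(=O)c1cc(OC)c(OC)c(OC)c1`, has not yet been measured. It keeps everything of compound 3 except one group: dibutylamino in place of (tert-butyl)amino on a carbonyl carbon. Within the data shown here, no two measured compounds differ by this change alone, so there is no measured step to lean on. In this assay a small step is expected, if any, in the direction of a weaker inhibitor, roughly a 1.5-fold higher number from compound 3 to compound 4 (0.19 log units; within the scatter). Compound 4 is therefore estimated at 200 nM, with a range from 50 nM to 800 nM.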

Compound 4, half-maximal inhibitory concentration: 1250 nM
Compound 4: the middle estimate sits 6.3-fold (0.80 log units) below what was measured; measured number above the stated range.
By their numbers in this assay, from the lowest: compound 3; then compound 4; then compound 2; then compound 1.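

In this assay this place on a carbonyl carbon proves sensitive: dibutylamino in place of (tert-butyl)amino gives a clearly weaker inhibitor (a 9.6-fold higher number from compound 3 to compound 4 (0.98 log units; beyond the scatter)). The change removes the one hydrogen-bond donor and also raises the group from 5 to 9 heavy atoms, so this single step cannot separate the two differences. No measurement shown here explains the loss. As far as these compounds go, it remains open which difference matters. Methylamino, which keeps the amide hydrogen on a small group, and dimethylamino, which lacks that hydrogen, would help to tell them apart.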